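Swapping furan-3-yl for phenyl in a cell toxicity test

The source may report more compounds than this note shows. Statements on the series, on what has been measured and on what is new or still open speak of the compounds shown alone.

Compound 1 `CNc1ncnc2c1c(-c1ccoc1)cn2[C@@H]1O[C@H](CO)[C@@H](O)[C@H]1O` gives > 100000 nM
Compound 2 `Cc1ncnc2c1c(-c1ccsc1)cn2[C@@H]1O[C@H](CO)[C@@H](O)[C@H]1O` gives > 100000 nM
Compound 3 `Cc1nc(N)c2c(-c3ccoc3)cn([C@@H]3O[C@H](CO)[C@@H](O)[C@H]3O)c2n1` gives > 100000 nM

These three compounds were tested in an ADME assay on MRC5 cells (Homo sapiens), read by MTT assay, with a stated time of 72 h; on this read-out lower numbers stand for stronger inhibition and higher numbers for weaker inhibition. Compound 3 reads > 100000 nM, and this is a limit of the assay, not a number. The other two values are limits as well, so all three compounds sit at the same mark (the limit of > 100000 nM in this assay, at which 3 of the 3 values shown sit). Among the compounds with values here, no pair among them differs in a single place, which leaves no measured step to serve as a guide.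

Compound 4 `Cc1nc(N)c2c(-c3ccccc3)cn([C@@H]3O[C@H](CO)[C@@H](O)[C@H]3O)c2n1` keeps the shared core of compound 3 and carries phenyl in place of furan-3-yl on an aromatic carbon. Within the data shown here, the only guide is the position of compound 3 at its limit (> 100000 nM). No change beyond the usual scatter is expected in this assay, and the estimated step is small (a number no higher from compound 3 to compound 4 (the limit leaves the size open)). The estimated value for compound 4 is 100000 nM, with an expected range from 30000 nM to 200000 nM.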

Compound 4, half-maximal inhibitory concentration: > 100000 nM
Compound 4 was reported as a limit (the forecaster's own chance of this, stated with the estimate: 80%); the middle value sits exactly at the limit.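

No step can be read from compound 3 to compound 4, since both values are limits of the assay and not numbers: the limit of > 100000 nM in this assay, at which 4 of the 4 values shown sit.

The compounds shown leave open how furan-3-yl and phenyl truly compare, and whether any change to the shared core gives a readable value in this assay at all.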